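A Ring Exchange on the Oxygen of Compound 2

This account rests on a few compounds, and the source may have more. Where it says the series, first, only, none or still open, it means among the compounds named here.

Measured in a functional assay on CAL-51 cells (Homo sapiens) for antiproliferative activity, read by luminescence and CellTiter-Glo, with a stated time of 3 days; on this read-out lower numbers stand for stronger inhibition and higher numbers for weaker inhibition:
- compound 1 `COc1cc(N2CCC(C)(O)CC2)ccc1Nc1nc(O[C@H]2CCOC(C)(C)C2)c2cc[nH]c2n1`: 71 nM
- compound 2 `COc1cc(C(=O)N(C)C)ccc1Nc1nc(O[C@H]2CCOC(C)(C)C2)c2cc[nH]c2n1`: 131 nM
- compound 3 `COc1cc(N2CCN(C(=O)CO)CC2)ccc1Nc1nc(O[C@H]2CCOC(C)(C)C2)c2cc[nH]c2n1`: 37 nM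

Going by the values given here, compound 2 stands clearly apart from only one neighbour, with a 3.5-fold lower number from compound 2 to compound 3 (0.55 log units; beyond the scatter), against a 1.8-fold higher number from compound 1 to compound 2 (0.27 log units; within the scatter). The remaining step is a 1.9-fold lower number from compound 1 to compound 3 (0.28 log units; within the scatter). Compound 4 `COc1cc(C(=O)N(C)C)ccc1Nc1nc(O[C@H]2CC[C@](C)(O)CC2)c2cc[nH]c2n1` changes compound 2 elsewhere: 4-hydroxy-4-methylcyclohexyl in place of 2,2-dimethyloxan-4-yl on an oxygen on an aromatic ring. Here, 4-hydroxy-4-methylcyclohexyl replaces 2,2-dimethyloxan-4-yl on an oxygen on an aromatic ring. All three measured steps concern a group on an aromatic carbon, so none tests this exchange directly. They show only how far the numbers moved at another place. Going by these compounds, no shift beyond the scatter is therefore expected, and the direction remains open, leaving the expected step as a 1.1-fold higher number from compound 2 to compound 4 (0.06 log units; within the scatter). Compound 4 is estimated at 150 nM, with an expected range of 45 nM to 500 nM.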

Compound 4, half-maximal inhibitory concentration: 69 nM
Estimate against measurement, compound 4: 2.2-fold (0.34 log units) above, within the range that was stated.
By their numbers in this assay, from the lowest: compounds 3, 4, 1 and 2 (each within the scatter of the next, the first and the last beyond it).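

At the oxygen on the aromatic ring, in this assay, 4-hydroxy-4-methylcyclohexyl in place of 2,2-dimethyloxan-4-yl gives a 1.9-fold lower number from compound 2 to compound 4 (0.28 log units; within the scatter). Going by these compounds alone, this is the first reading at this place, and it shows that a ring of carbon only, carrying a hydrogen-bond donor, can replace the oxygen-containing ring without a change beyond the scatter. Nothing available accounts for this result.

Going by these compounds, it remains open whether the exchange reads the same with the other groups on the aromatic carbon. Also open, on these data alone, is how an amine or a carboxylic acid would read in place of the hydroxy group on the cyclohexyl ring.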